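Carboxy in Place of Hydroxy: Expectation for Compound 4

This account rests on a few compounds, and the source may have more. Where it says the series, first, only, none or still open, it means among the compounds named here.

compound 1 `CCc1ccc2nc(C(=O)Nc3c(F)cc(-c4cccc(F)c4)cc3F)c(C)c(O)c2c1`: 56.3%
compound 2 `Cc1c(C(=O)Nc2c(F)cc(-c3cccc(F)c3)cc2F)nc2ccc(F)cc2c1O`: 41.2%
compound 3 `Cc1c(C(=O)Nc2c(F)cc(-c3cccc(F)c3)cc2F)nc2ccc(OC(F)(F)F)cc2c1O`: 41.3%

In a functional assay on Hep 3B2 cells (Homo sapiens) for antiproliferative activity, read by MTT assay, with a stated time of 24 h, tested at 33.33 ug/mL (a higher number here means a stronger effect of the compound at the concentration tested, a lower number a weaker effect), compound 2 stands lowest of the three numbers, although a number 0.1 percentage points higher from compound 2 to compound 3 (within the scatter), so compound 2 and compound 3 cannot be ordered; only a number 15.1 percentage points lower from compound 1 to compound 2 (beyond the scatter) and a number 15 percentage points lower from compound 1 to compound 3 (beyond the scatter) stand beyond the scatter. Compound 4 `Cc1c(C(=O)Nc2c(F)cc(-c3cccc(F)c3)cc2F)nc2ccc(F)cc2c1C(=O)O` differs from compound 2 by carboxy in place of hydroxy on an aromatic carbon. None of the three measured steps touches this change: each of them exchanges the ethyl, fluoro or trifluoromethoxy group, while the hydroxy group is kept in every measured compound. Among the measured compounds shown here, no measured step therefore bears on the change, and neither its direction nor its size can be read from these compounds. For compound 4 a value of 41% is expected, with a range from 15% to 65%. The expected step of a number 0.2 percentage points lower from compound 2 to compound 4 (within the scatter) is accordingly set at none beyond the scatter, with wide uncertainty.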

Compound 4, a percentage reported as inhibition, at one concentration (the size of the read-out at that concentration, not a potency): 34.3%
The estimate for compound 4 lay 6.7 percentage points above the measured number, within the range that was stated.
By their numbers in this assay, from the lowest: compounds 4, 2 and 3 (each within the scatter of the next); then compound 1.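

In this assay, the first change shown at this position, carboxy in place of hydroxy on an aromatic carbon, gives a number 6.9 percentage points lower from compound 2 to compound 4 (within the scatter). With the fluoro group kept, the hydroxy group can therefore be exchanged for carboxy without a step beyond the scatter, so this read-out does not depend on the hydroxy group in this pair. Nothing available explains this result. From the compounds shown here alone, it remains open whether an amine or a methoxy group would behave in the same way here, and whether carboxy would do so alongside the ethyl group of compound 1.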